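This account rests on a few compounds, and the source may have more. Where it says the series, first, only, none or still open, it means among the compounds named here.

- compound 1 `O=C1CSC(N2N=C(c3ccc(Br)cc3)CC2c2ccc3ccccc3c2)=N1` gives 11700 nM
- compound 2 `O=C1CSC(N2N=C(c3ccc(F)cc3)CC2c2ccc3ccccc3c2)=N1` gives 14900 nM

Among the measured compounds shown here, in a functional assay on BGC-823 cells (Homo sapiens) for inhibition, read by CCK-8 assay, with a stated time of 48 h (a lower number here means a stronger inhibitor, a higher number a weaker inhibitor), compound 2 cannot be separated from compound 1, its only measured neighbour, and the pair stands together in the low micromolar range of the read-out. Compound 3 `Cc1ccc(C2=NN(C3=NC(=O)CS3)C(c3ccc4ccccc4c3)C2)cc1C` is still unmeasured. It differs from compound 2 as follows: 3,4-dimethylphenyl in place of 4-fluorophenyl on a carbon with a double bond to nitrogen with 3,4-dimethylphenyl in place of 4-fluorophenyl on a carbon with a double bond to nitrogen.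

For the measured compounds named here, one measured step bears on this change, and it is small: a 1.3-fold higher number from compound 1 to compound 2 (0.11 log units; within the scatter) for fluoro in place of bromo on an aromatic carbon. That step covers only an exchange of one halogen for another. Going by the values given here, no measured compound carries methyl groups on this ring, so the evidence for the new group is indirect and the range is kept wide. The direction cannot be read from the data, and no shift beyond the scatter in this assay is expected. The estimated step is a 1.1-fold lower number from compound 2 to compound 3 (0.06 log units; within the scatter) and it stays small. Compound 3 is estimated at 13000 nM with an expected range from 6000 nM to 28000 nM in this read-out.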

Compound 3, half-maximal inhibitory concentration: 6020 nM
Compound 3: the middle estimate sits 2.2-fold (0.33 log units) above what was measured; measured number inside the range.
By their numbers in this assay, from the lowest: compounds 3, 1 and 2 (each within the scatter of the next, the first and the last beyond it).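

At this position, on a carbon with a double bond to nitrogen of the five-membered non-aromatic ring, the halogen exchange alone gave no separable difference, but in this assay 3,4-dimethylphenyl in place of 4-fluorophenyl gives a 2.5-fold lower number from compound 2 to compound 3 (0.39 log units; beyond the scatter) and so shows, modestly, that the number can respond to the group placed here. The same group in place of 4-bromophenyl gives a 1.9-fold lower number from compound 1 to compound 3 (0.29 log units; within the scatter), so the separation holds against compound 2 only, and compound 3 and compound 1 stay together. Whether the two methyl groups or the absence of a halogen matters cannot be told from these three compounds, and nothing beyond the numbers bears on the step.

Open, as far as these compounds go, is whether a single methyl group on this phenyl ring, or a methoxy group, an amine or a carboxylic acid in its place, would shift the number at this position. The large group and the rest of the shared core stay the same in all three compounds, so nothing shown here speaks to changes there.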